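Swapping an amino group on a shared core

The source may hold more compounds than are shown below. What is called first, only, known or untested is meant among the compounds shown, and "the series" means these compounds.

Compound 1 `NC1CC2(N3CCCC3)CC(c3ccccc3)C1C(c1ccccc1)C2` gives 38100 nM
Compound 2 `CN1CCN(CC(=O)N2CCC3(N(C)C)CC(c4ccccc4)C2C(c2ccccc2)C3)CC1` gives 195000 nM

In an ADME assay on L6 cells (Rattus norvegicus) for cytotoxicity, read by resazurin assay, with a stated time of 72 h (a lower number here means a stronger inhibitor, a higher number a weaker inhibitor), compound 1 has the lower of these two numbers, and its gap to compound 2 lies beyond the usual scatter of repeated measurements. Within the data shown here, compound 1 is therefore the more strongly inhibiting of the pair, though only two values are available.

The next compound, compound 3 `CCN(CC)CC(=O)OC1CC2(N3CCCC3)CC(c3ccccc3)C1C(c1ccccc1)C2`, keeps the core of compound 1 but has (((diethylamino)methyl)carbonyl)oxy in place of amino on a saturated ring carbon and this is a sizeable change at one place.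

Among the measured compounds shown here, no measured pair shows what this exchange does on its own, so any expectation is uncertain. Compound 2 also carries a side chain with a carbonyl and an amine, and its 195000 nM leaves room for a higher number, but it differs from compound 1 in more than one place. The step of a 1.1-fold lower number from compound 1 to compound 3 (0.04 log units; within the scatter) is therefore expected to stay within the usual scatter, in no firm direction.

For compound 3 the estimated value is 35000 nM with an expected range (10000 nM to 110000 nM).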

Compound 3, half-maximal inhibitory concentration: 49000 nM
For compound 3 the middle estimate is 1.4-fold (0.15 log units) below the measured one, and the stated range covers the measured number.
By their numbers in this assay, from the lowest: compounds 1 and 3 (each within the scatter of the next); then compound 2.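

In this assay, (((diethylamino)methyl)carbonyl)oxy in place of amino on this saturated ring carbon gives a 1.3-fold higher number from compound 1 to compound 3 (0.11 log units; within the scatter), so this read-out does not separate the two compounds. Among these compounds, this is the first one-place comparison at this position, and it shows that replacing a group of 1 heavy atom and 1 hydrogen-bond donor with one of 9 heavy atoms and 0 hydrogen-bond donors need not move the number beyond the scatter. No measurement is available to explain why the number stays within the scatter after so large an exchange.

This single pair says little about other groups at this position: a hydroxyl group, a carboxylic acid or a longer chain carrying the same diethylamino group could each move the number in either direction. Going by these compounds, it also remains open whether the same exchange would give a step within the scatter if a piperidin-1-yl group stood in place of the pyrrolidin-1-yl group on the shared core.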